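This account rests on a few compounds, and the source may have more. Where it says the series, first, only, none or still open, it means among the compounds named here.

In a physicochemical assay for solubility, read by spectrophotometry, in phosphate buffer, with a stated time of 18 h, at pH 7.4 (on this read-out higher numbers stand for higher solubility and lower numbers for lower solubility), compound 1 (`CCc1ccc(-c2nc3c(c(C)nn3-c3ccccc3)c(-c3ccccc3O)c2C#N)cc1`) gives 3100 nM, compound 2 (`CCc1ccc(-c2nc3c(c(C)nn3-c3ccccc3)c(-c3ccccc3Br)c2C#N)cc1`) gives 1500 nM and compound 3 (`CCc1ccc(-c2nc3c(c(C)nn3-c3ccccc3)c(-c3ccccc3S(C)(=O)=O)c2C#N)cc1`) gives 2200 nM. Compound 3 therefore sits within the scatter of both other compounds: a 1.4-fold lower number from compound 1 to compound 3 (0.15 log units; within the scatter), and a 1.5-fold higher number from compound 2 to compound 3 (0.17 log units; within the scatter).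

The next change leads to compound 4 (`CCc1ccc(-c2nc3c(c(C)nn3-c3ccccc3)c(-c3ccccc3OC(F)(F)F)c2C#N)cc1`), with trifluoromethoxy in place of methylsulfonyl on an aromatic carbon, ortho to a large group: trifluoromethoxy in place of methylsulfonyl on an aromatic carbon.

Within the data shown here, no measured compound carries trifluoromethoxy, so the evidence is indirect. The three measured steps all exchange groups at this same place. Only one goes beyond the scatter, and it is modest: a 2.1-fold lower number from compound 1 to compound 2 (0.32 log units; beyond the scatter). In this assay, exchanges at this place have so far moved the number little, though three compounds make a thin basis.

Bromo is taken as the closest measured match for trifluoromethoxy, a judgement from structure alone. Among the measured compounds shown here, that choice gives a slight lean towards compound 2 at 1500 nM, with no step clearly beyond the scatter expected. The expected step is a 1.6-fold lower number from compound 3 to compound 4 (0.20 log units; within the scatter).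

For compound 4, the estimated value is 1400 nM, with an expected range of 600 nM to 2800 nM.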

Compound 4, solubility: 9900 nM
The estimate for compound 4 lay 7.1-fold (0.85 log units) below the measured number; the whole stated range lies below it.
By their numbers in this assay, from the lowest: compounds 2, 3 and 1 (each within the scatter of the next, the first and the last beyond it); then compound 4.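

In this assay this position, on an aromatic carbon, ortho to a large group, proves more responsive than compound 1, compound 2 and compound 3 alone suggested: trifluoromethoxy gives a 4.5-fold higher number from compound 3 to compound 4 (0.65 log units; beyond the scatter) against methylsulfonyl, with a 6.6-fold higher number from compound 2 to compound 4 (0.82 log units; beyond the scatter) against bromo and a 3.2-fold higher number from compound 1 to compound 4 (0.50 log units; beyond the scatter) against the hydroxy group. With all three steps beyond the scatter, compound 4 has the highest number of the set, so bromo and trifluoromethoxy are not interchangeable at this position, and the small differences among the earlier groups do not set the limit of what a change here can do. Nothing available bears on why this exchange moves the number so much more than the earlier ones.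

A methoxy group, which keeps the oxygen without fluorine, and a trifluoromethyl group on the same carbon, which keeps fluorine without the oxygen, would show which part of trifluoromethoxy goes with the higher number. An amine or a carboxylic acid at this position remains an open comparison, as does whether trifluoromethoxy gives a similar step on a different version of the core.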